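Hydroxylamine in place of nitrile on an indole chain

The source may hold more compounds than are shown below. What is called first, only, known or untested is meant among the compounds shown, and "the series" means these compounds.

Measured so far:
Compound 1, `N#CCCCc1c[nH]c2ccc(F)cc12`, 72 nM
Compound 2, `NC(=O)CCc1c[nH]c2c(F)cccc12`, 64 nM
Compound 3, `NCCSCCCc1c[nH]c2c(F)cccc12`, > 100 nM

All three share the same fluorinated core and carry a short saturated chain that ends in a polar group. In an assay on isolated protein for inhibition of Myeloperoxidase (Homo sapiens), read by ELISA, with a stated time of 5 min (a higher number here means a weaker inhibitor, a lower number a stronger inhibitor), compound 1 gives 72 nM, and compound 2 gives 64 nM; these two numbers lie within the usual scatter of each other, so neither can be called the stronger inhibitor. Compound 3 reaches only the limit of this assay, > 100 nM, so its number is not known exactly. Among the compounds with values here, the one step between measured compounds, an at least 1.5-fold higher number from compound 2 to compound 3 (0.19 log units; that floor lies within the scatter), shows that swapping the polar end of the chain can cost potency, though the size of that step is set by a limit (the limit of > 100 nM in this assay, at which 1 of the 3 values shown sits).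

Compound 4, `ONCCCc1c[nH]c2ccc(F)cc12`, differs from compound 1 by hydroxyamino in place of cyano on a saturated chain carbon, three bonds along the chain from an aromatic carbon. Within the data shown here, no measured pair changes cyano to hydroxyamino, so the step from compound 2 to compound 3 is the only guide, and it points weaker rather than stronger. Still, the nitrile and hydroxyamino chains are both short and polar, so compound 4 is expected to stay close to compound 1, a 1.4-fold lower number from compound 1 to compound 4 (0.16 log units; within the scatter). Compound 4 is therefore estimated at 50 nM, within 12 nM to 200 nM.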

Compound 4, half-maximal inhibitory concentration: 21 nM
Beside the measured number, compound 4's estimate is 2.4-fold (0.38 log units) above it, within the range that was stated.
By their numbers in this assay, from the lowest: compound 4; then compounds 2 and 1 (each within the scatter of the next). At a limit, above all of these: compound 3.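

Putting hydroxyamino in place of the nitrile, on a saturated chain carbon three bonds along the chain from an aromatic carbon, gives in this assay a 3.4-fold lower number from compound 1 to compound 4 (0.54 log units; beyond the scatter). This is the only step shown with an exact size beyond the scatter, and it shows that a change at the end of this chain can make a stronger inhibitor, whereas the one earlier step pointed, if anywhere, towards a weaker one. The change swaps a cyano group with 0 hydrogen-bond donors and 1 acceptor for a hydroxyamino group with 2 of each, but nothing measured here links those counts, or any other feature of the two groups, to the gain.

From the compounds shown here alone, whether the oxygen of the hydroxyamino group matters remains open, since a plain amine or a carboxylic acid at the same chain end would be needed to separate its part from that of the nitrogen. Also open, going by these compounds, is whether the gain holds on a longer chain, or with hydroxyamino on the chain of compound 2, where the fluorine sits differently on the shared core.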